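Swapping methyl for nitro on an aromatic ring

The source may report more compounds than this note shows. Statements on the series, on what has been measured and on what is new or still open speak of the compounds shown alone.

Compound 1 (`O=C1CS/C(=N/c2ccccc2)N1Cc1ccncc1`) gives 26000 nM
Compound 2 (`Cc1ccc(/C=C2/S/C(=N/c3ccccc3)N(Cc3ccncc3)C2=O)cc1`) gives 19700 nM

In a functional assay on HepG2 cells (Homo sapiens) for cytotoxicity, read by MTT assay, with a stated time of 48 h (on this read-out higher numbers stand for weaker inhibition and lower numbers for stronger inhibition), compound 2 gives 19700 nM against compound 1 at 26000 nM and the two values lie within the usual scatter of each other, so neither ranks ahead.

Compound 3 (`O=C1/C(=C\c2ccc([N+](=O)[O-])cc2)S/C(=N/c2ccccc2)N1Cc1ccncc1`) differs from compound 2 in one place, 4-methylphenyl to 4-nitrophenyl (nitro in place of methyl on an aromatic carbon): nitro in place of methyl on an aromatic carbon. For the measured compounds named here, no measured pair shows this exchange, so the expectation starts from compound 2 (19700 nM) and carries little certainty. A small move towards stronger inhibition is expected in this assay and it may not clear the scatter. The expected change is modest (a 1.3-fold lower number from compound 2 to compound 3 (0.12 log units; within the scatter)). The estimate for compound 3 is 15000 nM (expected range from 6000 nM to 35000 nM).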

Compound 3, half-maximal inhibitory concentration: 18900 nM
Compound 3: middle estimate off by 1.3-fold (0.10 log units), on the low side, within the range that was stated.
By their numbers in this assay, from the lowest: compounds 3, 2 and 1 (each within the scatter of the next).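

In this assay, for the compounds shown here, placing nitro in place of methyl on this aromatic carbon, para to a large group, gives a 1.0-fold lower number from compound 2 to compound 3 (0.02 log units; within the scatter) and so provides the first direct reading of this exchange. At this position, a group of three heavy atoms with two hydrogen-bond acceptors replaces a single carbon with no hydrogen-bond acceptors, yet the two compounds cannot be told apart in this assay. Nothing available explains why the two compounds read alike.

The compounds shown leave open whether an amine or a carboxylic acid on this same carbon would also stay within the scatter of compound 2. They also leave open whether a longer chain there, such as propyl, would separate from compound 2 in this assay.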